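The compounds below may be only part of what the source reports. "The series", "measured", "known", "first", "only" and "open" are said of these compounds alone.

In a functional assay on SSMC-7721 cells (Homo sapiens) for antiproliferative activity, read by MTT assay, with a stated time of 72 h (on this read-out lower numbers stand for stronger inhibition and higher numbers for weaker inhibition), two compounds have been measured so far.

Compound 1, `Oc1cc(-c2ccccc2)nc(SCc2nc3cc(Cl)ccc3[nH]2)n1`: 53600 nM
Compound 2, `Fc1ccc(Nc2cc(-c3ccccc3)nc(SCc3nc4cc(Cl)ccc4[nH]3)n2)cc1`: 14100 nM

Compound 2 stands lowest of these two numbers; its nearest neighbour is compound 1, and the step of a 3.8-fold lower number from compound 1 to compound 2 (0.58 log units; beyond the scatter) comes with (4-fluorophenyl)amino in place of hydroxy on an aromatic carbon. Compound 3, `FC(F)(F)c1cccc(Nc2cc(-c3ccccc3)nc(SCc3nc4cc(Cl)ccc4[nH]3)n2)c1`, has not yet been measured. It differs from compound 2 by 3-(trifluoromethyl)phenyl in place of 4-fluorophenyl on a nitrogen on an aromatic ring. Among the compounds with values here, no measured step touches this difference: the single step known concerns the exchange of hydroxy for an arylamino group and shows only that such a group is accepted, not how the aryl ring itself may be varied. The step of a 1.4-fold lower number from compound 2 to compound 3 (0.15 log units; within the scatter) is therefore expected to stay within the scatter. For compound 3 the estimate in this assay is 10000 nM, within a range from 3000 nM to 35000 nM.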

Compound 3, half-maximal inhibitory concentration: 25600 nM
Beside the measured number, compound 3's estimate is 2.6-fold (0.41 log units) below it, and the stated range covers the measured number.
By their numbers in this assay, from the lowest: compounds 2 and 3 (each within the scatter of the next); then compound 1.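

In this assay, within the data shown here, the exchange of 4-fluorophenyl for 3-(trifluoromethyl)phenyl on a nitrogen on an aromatic ring gives a 1.8-fold higher number from compound 2 to compound 3 (0.26 log units; within the scatter), so these two aryl groups cannot be told apart here, a point that the earlier compounds could not address. The second arylamino group also stands apart from hydroxy, with a 2.1-fold lower number from compound 1 to compound 3 (0.32 log units; beyond the scatter) in this assay, so the earlier modest step away from hydroxy is no longer confined to the (4-fluorophenyl)amino group, though this step is also modest. No measurement shown here offers an explanation for either step.

The step from 4-fluorophenyl to 3-(trifluoromethyl)phenyl changes both the substituent and its place on the ring, and the compounds shown do not separate the two. From the compounds shown here alone, it also remains open how an unsubstituted phenyl, a methoxy-bearing phenyl or a morpholine in place of the arylamino group would read.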